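Aryl swap on the ring nitrogen of a diaryl urea

The source may report more compounds than this note shows. Statements on the series, on what has been measured and on what is new or still open speak of the compounds shown alone.

Measured so far:
Compound 1, `N#Cc1cccc(-n2cc(COc3cccc(NC(=O)Nc4ccc(Cl)c(C(F)(F)F)c4)c3)nn2)c1`, 2760 nM
Compound 2, `O=C(Nc1cccc(OCc2cn(-c3cccc(F)c3)nn2)c1)Nc1ccc(Cl)c(C(F)(F)F)c1`, 2120 nM

Both compounds were tested in a functional assay on HepG2 cells (Homo sapiens) for inhibition, read by MTT assay, with a stated time of 72 h; a lower number here means a stronger inhibitor, a higher number a weaker inhibitor. Within the data shown here, compound 2, with its value of 2120 nM, has the lowest of the two numbers; compound 1, at 2760 nM, sits nearest, and the single measured step, a 1.3-fold lower number from compound 1 to compound 2 (0.11 log units; within the scatter), lies within the scatter. The two values therefore cannot be ordered.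

Compound 3, `O=C(Nc1cccc(OCc2cn(-c3ccc(Cl)cc3)nn2)c1)Nc1ccc(Cl)c(C(F)(F)F)c1`, has not yet been measured. It differs from compound 2 in one place: 4-chlorophenyl in place of 3-fluorophenyl on an aromatic nitrogen. Among the measured compounds shown here, the only measured step that bears on a change at this position is the one from compound 1 to compound 2, which exchanged one substituent on this aryl group for another and produced no movement beyond the scatter. On that evidence, compound 3 is expected to stay close to compound 2, with the step of a 1.1-fold lower number from compound 2 to compound 3 (0.03 log units; within the scatter) amounting to no more than the scatter allows. The estimate for compound 3 in this assay is 2000 nM, within a range from 800 nM to 5000 nM.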

Compound 3, half-maximal inhibitory concentration: 2490 nM
Beside the measured number, compound 3's estimate is 1.2-fold (0.10 log units) below it; low and high end bracket the measured number.
By their numbers in this assay, from the lowest: compounds 2, 3 and 1 (each within the scatter of the next).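

In this assay, the exchange of 3-fluorophenyl for 4-chlorophenyl on the aromatic nitrogen gives a 1.2-fold higher number from compound 2 to compound 3 (0.07 log units; within the scatter), and the exchange of 3-cyanophenyl for 4-chlorophenyl gives a 1.1-fold lower number from compound 1 to compound 3 (0.04 log units; within the scatter). Among these compounds, the earlier pair compared only two groups that both carry their substituent at the 3 position of the phenyl ring; compound 3 adds a group with a different halogen at the 4 position, and all three compounds still cannot be told apart in this assay. Thus, across 3-cyanophenyl, 3-fluorophenyl and 4-chlorophenyl, the identity of the aryl group at this position has no readable bearing on the number, and no other measurement is available that bears on this result.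

The compounds shown leave open whether the numbers would remain this close with an amine or a carboxylic acid on the phenyl ring, or with a plain alkyl chain in place of the aryl group on the aromatic nitrogen. Going by these compounds, the urea and its ring bearing chloro and trifluoromethyl groups are the same in all three compounds, so the effect of a change there also remains open.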